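Series notes on cytotoxicity toward compound 4

This account rests on a few compounds, and the source may have more. Where it says the series, first, only, none or still open, it means among the compounds named here.

Measured so far:
compound 1 `O=C(/C=C/c1ccc2c(c1)B(O)OC2)c1cccnc1` — 34400 nM
compound 2 `CSc1ccc(C(=O)/C=C/c2ccc3c(c2)B(O)OC3)cc1` — 7400 nM
compound 3 `O=C(/C=C/c1ccc2c(c1)B(O)OC2)c1ccc(C(F)(F)F)cc1` — 22300 nM

In a toxicity assay on MCF-10A cells (Homo sapiens) for cytotoxicity, read by MTT assay, with a stated time of 48 h (on this read-out lower numbers stand for stronger inhibition and higher numbers for weaker inhibition), compound 1 stands at the highest of the three numbers; compound 3 lies within the scatter of it, while compound 2 lies beyond the scatter at a lower number. Compound 4 `O=C(/C=C/c1ccc2c(c1)B(O)OC2)c1ccccc1F` differs from compound 1 by 2-fluorophenyl in place of pyridin-3-yl on a carbonyl carbon. Within the data shown here, the only measured step, a 3.0-fold higher number from compound 2 to compound 3 (0.48 log units; beyond the scatter), also exchanges the group on the carbonyl carbon, but neither of its groups is pyridin-3-yl or 2-fluorophenyl, so it bears only loosely here. It shows that this position can move the read-out by a modest amount. The expected step is a 1.6-fold lower number from compound 1 to compound 4 (0.19 log units; within the scatter). Compound 4 is estimated at 22000 nM, within 9000 nM to 50000 nM.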

Compound 4, half-maximal inhibitory concentration: 25400 nM
The estimate for compound 4 lay 1.2-fold (0.06 log units) below the measured number, within the range that was stated.
By their numbers in this assay, from the lowest: compound 2; then compounds 3, 4 and 1 (each within the scatter of the next).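

In this assay the exchange on the carbonyl carbon gives a 1.4-fold lower number from compound 1 to compound 4 (0.13 log units; within the scatter) so pyridin-3-yl and 2-fluorophenyl are not told apart here, even though a hydrogen-bond acceptor leaves with the pyridin-3-yl. The position does not respond to every exchange: a 3.0-fold higher number from compound 2 to compound 3 (0.48 log units; beyond the scatter) lies beyond the scatter, while this new step lies within it. Nothing on hand accounts for either outcome. From the compounds shown here alone, whether an amine or a carboxylic acid in place of these aromatic groups on the carbonyl carbon would move the number remains open.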